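The compounds below may be only part of what the source reports. "The series", "measured", "known", "first", "only" and "open" are said of these compounds alone.

Working notes on the series. Compound 1 `O=C(CSc1nccn1-c1ccc(Cl)cc1)Nc1ccccc1[N+](=O)[O-]` gives in an ADME assay on MT4 cells (Homo sapiens) for cytotoxicity, read by MTT assay (a lower number here means that less compound is tolerated, a higher number that more compound is tolerated), a value of > 321000 nM, which is a limit of the assay and not a number; one of the three results shown sits at this limit (the limit of > 321000 nM in this assay, at which 1 of the 3 values shown sits). Compound 2 `Cc1ccccc1NC(=O)CSc1nccn1-c1ccc(Cl)cc1` gives 160000 nM in this assay. Compound 3 `Cc1ccc(-n2ccnc2SCC(=O)Nc2ccccc2[N+](=O)[O-])cc1` gives 131000 nM in this assay; compound 2 and compound 3 lie within the scatter of each other.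

From compound 1 to compound 2 the change is methyl in place of nitro on an aromatic carbon, and the step is an at least 2.0-fold lower number from compound 1 to compound 2 (0.30 log units; that floor lies within the scatter), a floor set by the limit of compound 1. The cores of compound 1 and compound 3 differ by methyl in place of chloro on an aromatic carbon, a step of an at least 2.4-fold lower number from compound 1 to compound 3 (0.38 log units; beyond the scatter).

Compound 4 `Cc1ccc(-n2ccnc2SCC(=O)Nc2ccccc2C)cc1` is not yet measured. It differs from compound 3 by methyl in place of nitro on an aromatic carbon, the same change as from compound 1 to compound 2, at the same place. Beside the earlier step, the expected step in this assay is a 1.5-fold lower number from compound 3 to compound 4 (0.16 log units; within the scatter), resting on an at least 2.0-fold lower number from compound 1 to compound 2 (0.30 log units; that floor lies within the scatter) from compound 1, whose floor lies within the scatter. Compound 4 is estimated at 90000 nM, expected between 45000 nM and 200000 nM.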

Compound 4, half-maximal cytotoxic concentration: 147000 nM
Compound 4: middle estimate off by 1.6-fold (0.21 log units), on the low side; measured number inside the range.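

On the core of compound 3, methyl in place of nitro on an aromatic carbon gives a 1.1-fold higher number from compound 3 to compound 4 (0.05 log units; within the scatter), and on the core of compound 2, methyl in place of chloro on an aromatic carbon gives a 1.1-fold lower number from compound 2 to compound 4 (0.04 log units; within the scatter), so neither new step in this assay moves beyond the scatter. For the nitro change, this shows no measurable step on the core of compound 3, but it does not show whether the change carries over unaltered from the core of compound 1: the same change on two cores in this assay, an at least 2.0-fold lower number (0.30 log units; that floor lies within the scatter) from compound 1 to compound 2 and a 1.1-fold higher number (0.05 log units; within the scatter) from compound 3 to compound 4; the limit leaves it open whether they differ For the chloro change, the reading is equally small on the core of compound 2, and again it does not settle whether the size of the step is shared between cores: the same change on two cores in this assay, an at least 2.4-fold lower number (0.38 log units; beyond the scatter) from compound 1 to compound 3 and a 1.1-fold lower number (0.04 log units; within the scatter) from compound 2 to compound 4; the limit leaves it open whether they differ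

The compounds shown carry only nitro, methyl and chloro at the two places that vary, so the effect of an amine, a carboxylic acid or a longer chain at either place stays open. From the compounds shown here alone, whether these steps hold on any other core also stays open.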